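Bromo to fluoro at the aryl on the shared core

A few compounds are considered here, and "the series" means these few. Any claim that something is new, unique, unknown or untested is made for them only; others in the source may bear on it.

Measured compounds:
Compound 1 `CC(=O)Oc1ccc(/C=C/C(=O)OCCSc2nc(-c3ccc(S(N)(=O)=O)cc3)n(-c3ccccc3)n2)cc1OC(C)=O` gives 1110 nM in an assay on cells (strain Sprague-Dawley) for inhibition of Polyunsaturated fatty acid 5-lipoxygenase (Rattus norvegicus), with a stated time of 30 min; on this read-out lower numbers stand for stronger inhibition and higher numbers for weaker inhibition.
Compound 2 `CS(=O)(=O)c1ccc(-c2nc(SCCOC(=O)/C=C/c3ccc(O)c(O)c3)nn2-c2ccccc2)cc1` gives 850 nM in this assay.
Compound 3 `CS(=O)(=O)c1ccc(-c2nc(SCCCOC(=O)/C=C/c3ccc(O)c(O)c3)nn2-c2ccc(Br)cc2)cc1` gives 790 nM in this assay.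

Compound 3 carries the lowest of the three numbers, but its gap to compound 2 and its gap to compound 1 both lie within the scatter, so the three compounds are not separated in this assay. The untested compound 4 `CS(=O)(=O)c1ccc(-c2nc(SCCCOC(=O)/C=C/c3ccc(O)c(O)c3)nn2-c2ccc(F)cc2)cc1` keeps the core of compound 3 and differs in one place: fluoro in place of bromo on an aromatic carbon, which read one bond further out is 4-bromophenyl to 4-fluorophenyl, sitting on an aromatic carbon of a six-membered aromatic ring of carbon only, para to a large group.

Among the measured compounds shown here, no step between two measured compounds bears on this exchange, so nothing gives it a direction. The expected step of a 1.1-fold higher number from compound 3 to compound 4 (0.06 log units; within the scatter) is therefore none beyond the scatter. Compound 4 is estimated at 900 nM in this assay, with a range from 450 nM to 1800 nM.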

Compound 4, half-maximal inhibitory concentration: 710 nM
Beside the measured number, compound 4's estimate is 1.3-fold (0.10 log units) above it, and the stated range covers the measured number.
By their numbers in this assay, from the lowest: compounds 4, 3, 2 and 1 (each within the scatter of the next).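

In this assay, the first exchange measured at this position gives a 1.1-fold lower number from compound 3 to compound 4 (0.05 log units; within the scatter), so the 4-bromophenyl and 4-fluorophenyl forms of the shared core are not separated. On this pair, the size of the halogen's single heavy atom on the aromatic carbon leaves no readable mark on the number, and the series stays in the same range with either halogen in place. Nothing on hand accounts for this result.

Open, on these data alone, is whether a group other than a halogen on this aromatic carbon, such as an amine, a carboxylic acid or a methoxy group, would move the number beyond the scatter. Also open, as far as these compounds go, is how a longer chain in the linker to the ester would read with fluoro held in place.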